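Swapping Fluoro for Methoxy on a Shared Core

This account rests on a few compounds, and the source may have more. Where it says the series, first, only, none or still open, it means among the compounds named here.

Measured compounds:
compound 1, `O=C1CCCC2=C1C(c1ccc(F)cc1)C=C(c1ccccc1)N2`, 21.9%
compound 2, `CC1(C)CC(=O)C2=C(C1)NC(C(=O)O)=CC2c1ccccc1`, 17.1%

Of the compounds shown here, two have been tested so far in an assay on isolated protein for inhibition of glucose-6-phosphatase catalytic subunit 1 (Homo sapiens), read by inositol phosphate accumulation, with a stated time of 30 min, tested at 100 uM; on this read-out lower numbers stand for less inhibition and higher numbers for more inhibition at the one concentration tested (going by the name of the read-out). Compound 1 gives 21.9%, and compound 2 gives 17.1%. Compound 1 carries the higher of the two numbers, but the gap to compound 2 lies within the usual scatter of this measurement, so the two cannot be told apart.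

Compound 3, `COc1ccc(C2C=C(c3ccccc3)NC3=C2C(=O)CCC3)cc1`, has not yet been measured. Compared with compound 1, it differs at one place: methoxy in place of fluoro on an aromatic carbon. The rest of the shared core and the phenyl group remain unchanged.

Within the data shown here, no measured pair shows the effect of this change, so nothing here points to a direction. The step of a number 0.1 percentage points higher from compound 1 to compound 3 (within the scatter) is expected to stay within the scatter. Compound 3 is therefore estimated at 22%, with a range from 8% to 38%.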

Compound 3, a percentage reported as inhibition, at one concentration (the size of the read-out at that concentration, not a potency): 17.3%
Estimate against measurement, compound 3: 4.7 percentage points above, within the range that was stated.
By their numbers in this assay, from the lowest: compounds 2, 3 and 1 (each within the scatter of the next).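

Among these compounds, putting methoxy in place of fluoro, para to a large group on the six-membered aromatic ring, gives the first measured step at this position, a number 4.6 percentage points lower from compound 1 to compound 3 (within the scatter). In this assay the 4-fluorophenyl and 4-methoxyphenyl versions therefore cannot be told apart, even though methoxy is counted with a hydrogen-bond acceptor and fluoro with none. No measurement shown here offers an explanation of this result.

On these data alone, a single swap between two groups cannot show whether this position matters in general, so it remains open whether an amine, a carboxylic acid or a longer chain such as butoxy in the same place would move the number beyond the scatter. As far as these compounds go, the effect of changing the unaltered phenyl group on the shared core also remains open.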